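The compounds below may be only part of what the source reports. "The series", "measured", "known", "first", "only" and "open" are said of these compounds alone.

Measured so far:
- compound 1 `CO[C@@H]1CC=C2NN(c3ccc(C)cc3)C(=O)C[C@]2(C)O1`: 21500 nM
- compound 2 `CO[C@@H]1CC=C2NN(c3ccc(C)cc3)C(=O)C[C@]2(c2ccncc2)O1`: 5900 nM

Both numbers come from a functional assay on A549 cells (Homo sapiens) for inhibition, read by sulforhodamine B assay, with a stated time of 48 h; on this read-out lower numbers stand for stronger inhibition and higher numbers for weaker inhibition. Among the compounds with values here, on the two values at hand, compound 1 holds the highest number; its nearest neighbour is compound 2, and the change a 3.6-fold lower number from compound 1 to compound 2 (0.56 log units; beyond the scatter) is the only step recorded so far, modest in size and at a saturated ring carbon.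

Compound 3 `CO[C@@H]1CC=C2NN(c3cncnc3)C(=O)C[C@]2(C)O1` is not yet measured. It differs from compound 1 at a different place: pyrimidin-5-yl in place of 4-methylphenyl on an amide-type nitrogen in a ring. Within the data shown here, no measured pair changes the group on the amide-type nitrogen, so the step from compound 2 gives no direct guide here; it concerns a different position and is carried over only as an indication of how large a single change has moved the numbers. With nothing that bears on the change itself, the expectation for compound 3 is a step within the scatter, in no preferred direction, so a 1.1-fold higher number from compound 1 to compound 3 (0.05 log units; within the scatter) is the estimated movement from compound 1. Compound 3 is therefore expected to give about 24000 nM in this assay, with a plausible range from 8000 nM to 70000 nM.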

Compound 3, half-maximal inhibitory concentration: 4100 nM
The estimate for compound 3 lay 5.9-fold (0.77 log units) above the measured number; the measured number lies below the stated range.
By their numbers in this assay, from the lowest: compounds 3 and 2 (each within the scatter of the next); then compound 1.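

In this assay the group on the amide-type nitrogen proves to be a position that moves the number, and the change of 4-methylphenyl to pyrimidin-5-yl gives a step beyond the scatter (a 5.2-fold lower number from compound 1 to compound 3 (0.72 log units; beyond the scatter)). Within the data shown here, this is the first reading at this position, and it shows that the aryl group there need not be a carbon-only ring: a six-membered aromatic ring with 2 hetero atoms and 2 hydrogen-bond acceptors is tolerated, with the number moving downward. Nothing measured here explains the step.

Among these compounds, the single pair does not separate the loss of the methyl group from the entry of the ring nitrogens, and a plain phenyl or a pyridin-3-yl on the same nitrogen would be needed to tell these apart. Also open, from the compounds shown here alone, is whether this step combines with the change at the saturated ring carbon (a 3.6-fold lower number from compound 1 to compound 2 (0.56 log units; beyond the scatter)) when pyrimidin-5-yl and pyridin-4-yl stand together on the shared core.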